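Lengthening the oxime ether chain in a quinone series

The source may report more compounds than this note shows. Statements on the series, on what has been measured and on what is new or still open speak of the compounds shown alone.

Three compounds share one core and carry an oxime ether chain of different length. Compound 2 `CO/N=C/c1cc(OC)c2c(c1OC)C(=O)C=CC2=O` gives 0.109 ug/mL in a functional assay on L1210 cells (Mus musculus) for antiproliferative activity; a lower number here means that less compound is needed, a higher number that more compound is needed for the effect; compound 3 `CCCO/N=C/c1cc(OC)c2c(c1OC)C(=O)C=CC2=O` gives 0.107 ug/mL; compound 1 `CCCCCCCO/N=C/c1cc(OC)c2c(c1OC)C(=O)C=CC2=O` gives 0.213 ug/mL. The step of a 2.0-fold higher number from compound 2 to compound 1 (0.29 log units; within the scatter) comes from hexyl in place of hydrogen on a saturated chain carbon bound to an oxygen on an unsaturated carbon, and a 1.0-fold lower number from compound 2 to compound 3 (0.01 log units; within the scatter) from ethyl in place of hydrogen on a saturated chain carbon bound to an oxygen on an unsaturated carbon. Compound 4 `CCCCCCCCCO/N=C/c1cc(OC)c2c(c1OC)C(=O)C=CC2=O` is not yet measured; it differs from compound 3 by hexyl in place of hydrogen on a saturated chain carbon, three bonds along the chain from an oxygen on an unsaturated carbon. This is the same kind of change as in hexyl in place of hydrogen on a saturated chain carbon bound to an oxygen on an unsaturated carbon, but the place differs: there the new group sits on a carbon bound to the oxygen, here three bonds along the chain from it. Because a 2.0-fold higher number from compound 2 to compound 1 (0.29 log units; within the scatter) is small, a modest step of a 2.3-fold higher number from compound 3 to compound 4 (0.37 log units; beyond the scatter) is expected, giving an estimate of 0.25 ug/mL for compound 4, within 0.1 ug/mL to 0.7 ug/mL.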

Compound 4, concentration for half-maximal effect: 0.19 ug/mL
Compound 4: the middle estimate sits 1.3-fold (0.12 log units) above what was measured; low and high end bracket the measured number.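

In this assay, hexyl in place of hydrogen gives much the same result on both starting chains, with a 1.8-fold higher number from compound 3 to compound 4 (0.25 log units; within the scatter) matching the earlier step: the same change on two cores in this assay, a 2.0-fold higher number (0.29 log units; within the scatter) from compound 2 to compound 1 and a 1.8-fold higher number (0.25 log units; within the scatter) from compound 3 to compound 4, 1.1-fold (0.04 log units) apart, within the scatter of two such steps. The ethyl change also carries over, with a 1.1-fold lower number from compound 1 to compound 4 (0.05 log units; within the scatter) lying close to its earlier counterpart: the same change on two cores in this assay, a 1.0-fold lower number (0.01 log units; within the scatter) from compound 2 to compound 3 and a 1.1-fold lower number (0.05 log units; within the scatter) from compound 1 to compound 4, 1.1-fold (0.04 log units) apart, within the scatter of two such steps. Yet a 1.7-fold higher number from compound 2 to compound 4 (0.24 log units; within the scatter) also lies within the scatter, as do all these steps, so the agreement shows that the changes behave alike across these chains, not that lengthening the chain moves the number at all, and it says nothing about any core other than the shared one.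

Still open, from the compounds shown here alone, is whether an amine or a carboxylic acid in the chain, or a chain longer than nonyl, would move the number beyond the scatter.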